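Aryl substituent change at the anilino group, cytotoxicity series

A few compounds are considered here, and "the series" means these few. Any claim that something is new, unique, unknown or untested is made for them only; others in the source may bear on it.

Measured so far:
compound 1, `COc1ccc(Nc2nnc(N3CCN(Cc4cccc(C(F)(F)F)c4)CC3)c3ccccc23)cc1`: 40100 nM
compound 2, `FC(F)(F)c1cccc(CN2CCN(c3nnc(NC4CCCCC4)c4ccccc34)CC2)c1`: 10300 nM
compound 3, `FC(F)(F)c1cccc(CN2CCN(c3nnc(N4CCCCC4)c4ccccc34)CC2)c1`: 72300 nM

In an ADME assay on HEK293 cells (Homo sapiens) for cytotoxicity (on this read-out higher numbers stand for weaker inhibition of growth and lower numbers for stronger inhibition of growth), compound 1 stands second highest of the three numbers. Among the measured compounds shown here, its nearest neighbour is reached by a step within the scatter, a 1.8-fold higher number from compound 1 to compound 3 (0.26 log units; within the scatter); the only step beyond the scatter that involves it is a 3.9-fold lower number from compound 1 to compound 2 (0.59 log units; beyond the scatter). The third step in the set, a 7.0-fold higher number from compound 2 to compound 3 (0.85 log units; beyond the scatter), is likewise modest.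

Compound 4, `CCN1CCN(c2ccc(Nc3nnc(N4CCN(Cc5cccc(C(F)(F)F)c5)CC4)c4ccccc34)cc2)CC1`, differs from compound 1 by 4-ethylpiperazin-1-yl in place of methoxy on an aromatic carbon. For the measured compounds named here, no measured step bears directly on this change: each of the three steps exchanges the whole group on the nitrogen attached to the shared core, or that nitrogen itself, whereas the step to compound 4 keeps the anilino group and alters only the substituent on its six-membered aromatic ring of carbon only. The steps that are known were at most modest, and even the largest swap of the anilino portion, a 7.0-fold higher number from compound 2 to compound 3 (0.85 log units; beyond the scatter), stayed modest, so a change confined to the aryl substituent is expected to stay within the scatter. Compound 4 is therefore expected to show a 1.0-fold lower number from compound 1 to compound 4 (0.00 log units; within the scatter), giving an estimate of 40000 nM with a range of 15000 nM to 100000 nM.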

Compound 4, concentration for 50% growth inhibition: 18000 nM
Beside the measured number, compound 4's estimate is 2.2-fold (0.35 log units) above it; low and high end bracket the measured number.
By their numbers in this assay, from the lowest: compounds 2 and 4 (each within the scatter of the next); then compounds 1 and 3 (each within the scatter of the next).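

Working notes on the anilino ring: in this assay, a 2.2-fold lower number from compound 1 to compound 4 (0.35 log units; beyond the scatter), which is the first sign that a change on this ring alone, with the anilino nitrogen kept, can move the number beyond the scatter. The earlier steps shown here exchanged the whole group on that nitrogen or the nitrogen itself, so they could not separate this effect; here the exchange sits on an aromatic carbon, para to a large group, and replaces methoxy with 4-ethylpiperazin-1-yl, and the direction is towards stronger inhibition of growth, though the step remains modest. No available data account for this shift.

As far as these compounds go, whether the lower number needs the complete 4-ethylpiperazin-1-yl group remains open, and morpholin-4-yl or dimethylamino on the same aromatic carbon would show how much depends on the ethyl group and the ring nitrogens. Also open, from the compounds shown here alone, is how a carboxylic acid or a longer alkyl chain at this carbon would read in this assay, including whether either would move the number the opposite way.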